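Cyclooctyl replaces sec-butyl on the amide nitrogen

A few compounds are considered here, and "the series" means these few. Any claim that something is new, unique, unknown or untested is made for them only; others in the source may bear on it.

Three compounds share one core, differing only in what sits on the amide nitrogen. Compound 1 `NC(=O)[C@H]1OC(n2cnc3c(N)ncnc32)[C@H](O)[C@@H]1O` carries hydrogen there and in an assay on cell membranes for binding affinity to 2-oxoglutarate receptor 1 (Rattus norvegicus), read by radioligand binding (a higher number here means a weaker inhibitor, a lower number a stronger inhibitor), gives 64 nM. Compound 2 `CCCCCCCCNC(=O)[C@H]1OC(n2cnc3c(N)ncnc32)[C@H](O)[C@@H]1O` carries octyl and in this assay gives 21 nM. Compound 3 `CCC(C)NC(=O)[C@H]1OC(n2cnc3c(N)ncnc32)[C@H](O)[C@@H]1O` carries sec-butyl and gives 198 nM, the highest of the three numbers; a 9.4-fold higher number from compound 2 to compound 3 (0.97 log units; beyond the scatter), and a 3.1-fold higher number from compound 1 to compound 3 (0.49 log units; beyond the scatter). Compound 4 `Nc1ncnc2c1ncn2C1O[C@H](C(=O)NC2CCCCCCC2)[C@@H](O)[C@H]1O` is not yet measured; its change is cyclooctyl in place of sec-butyl on an amide-type nitrogen. The relevant steps are a 3.0-fold lower number from compound 1 to compound 2 (0.48 log units; beyond the scatter) and a 9.4-fold higher number from compound 2 to compound 3 (0.97 log units; beyond the scatter): the eight-carbon chain gave the lowest number, the short branched group the highest. An eight-carbon ring is therefore expected to move the number down, a 5.0-fold lower number from compound 3 to compound 4 (0.69 log units; beyond the scatter). Compound 4 is estimated at 40 nM, within 10 nM to 160 nM.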

Compound 4, inhibition constant: 23 nM
Estimate against measurement, compound 4: 1.7-fold (0.24 log units) above; the measured number falls inside the stated range.
By their numbers in this assay, from the lowest: compounds 2 and 4 (each within the scatter of the next); then compound 1; then compound 3.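

Closing the eight-carbon chain into a ring leaves the number where it was (a 1.1-fold higher number from compound 2 to compound 4 (0.04 log units; within the scatter)), so on this amide-type nitrogen the compounds shown do not separate cyclooctyl from octyl. Cyclooctyl also improves on sec-butyl (an 8.6-fold lower number from compound 3 to compound 4 (0.93 log units; beyond the scatter)) and on hydrogen (a 2.8-fold lower number from compound 1 to compound 4 (0.44 log units; beyond the scatter)): both eight-carbon groups sit below hydrogen, while sec-butyl, the exception, sits above it. No measurement here explains this difference. The compounds shown leave open where a cyclopentyl ring or a straight butyl chain would fall. Also open, as far as these compounds go, is whether an amine at the end of the octyl chain would keep the low number.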